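A few compounds are considered here, and "the series" means these few. Any claim that something is new, unique, unknown or untested is made for them only; others in the source may bear on it.

Going by the values given here, compound 1 `COc1ccccc1-c1nc2ccccc2[nH]1` gives 52.8% in a functional assay on the whole organism (ileum) with Rattus norvegicus as the target (a higher number here means a larger maximal response, a lower number a smaller maximal response), the higher of the two numbers measured so far. Among the compounds with values here, compound 2 `Clc1ccc(COc2ccccc2-c2nc3ccccc3[nH]2)cc1` gives 38.2% in this assay, and a number 14.6 percentage points lower from compound 1 to compound 2 (beyond the scatter) is the only measured step. Compound 3 `O=[N+]([O-])c1ccccc1-c1nc2ccccc2[nH]1` differs from compound 1 by nitro in place of methoxy on an aromatic carbon. Within the data shown here, that single measured step concerns a different place on the shared core, so it bears on this change only loosely, and no measured step of this kind exists; the expected step is a number 7.8 percentage points lower from compound 1 to compound 3 (within the scatter). Compound 3 is therefore estimated at 45%, with a range from 25% to 65%.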

Compound 3, largest response reached (Emax), in percent of the reference or control that the assay uses: 11.1%
Estimate against measurement, compound 3: 33.9 percentage points above; the measured number lies below the stated range.
By their numbers in this assay, from the lowest: compound 3; then compound 2; then compound 1.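

Going by these compounds alone, the substituent on this aromatic carbon matters far more than the earlier compounds could show: with nitro in place of methoxy, this assay gives a number 41.7 percentage points lower from compound 1 to compound 3 (beyond the scatter), a large step beyond the scatter. Within the data shown here, the only earlier step, a number 14.6 percentage points lower from compound 1 to compound 2 (beyond the scatter), was modest and lay at a different place on the shared core. Nothing shown here explains the drop. From the compounds shown here alone, with only methoxy and nitro compared at this carbon, it remains open whether an amine, a hydroxyl group or a plain hydrogen there would keep the response near that of compound 1 or lower it toward that of compound 3.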